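Working notes: compound 4 from compound 2

A few compounds are considered here, and "the series" means these few. Any claim that something is new, unique, unknown or untested is made for them only; others in the source may bear on it.

Compound 2 `COc1ccc(-c2cc3nccc(-c4cc(OC)c(OC)c(OC)c4)n3n2)cc1F` gives 183 nM in a functional assay on MCF7 cells (Homo sapiens) for inhibition, read by CCK-8 assay, with a stated time of 48 h (a lower number here means a stronger inhibitor, a higher number a weaker inhibitor), the lowest of the two numbers in hand; compound 1 `COc1cc(-c2ccnc3cc(-c4ccc(Cl)cc4)nn23)cc(OC)c1OC` gives 2320 nM in the same assay. Compound 3 `Cc1ccc(-c2cc3nccc(-c4ccc(F)cc4)n3n2)cc1` returns only a limit of this assay, > 10000 nM, not a number (the limit of > 10000 nM in this assay, at which 1 of the 3 values shown sits).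

Compound 4 `COc1cc(-c2ccnc3cc(-c4ccc(F)cc4)nn23)cc(OC)c1OC` differs from compound 2 by 4-fluorophenyl in place of 3-fluoro-4-methoxyphenyl on an aromatic carbon. For the measured compounds named here, the single measured step that bears on this exchange is a 13-fold lower number from compound 1 to compound 2 (1.10 log units; beyond the scatter), where the 4-chlorophenyl of compound 1 was replaced by the 3-fluoro-4-methoxyphenyl of compound 2. Compound 4 carries a 4-fluorophenyl, a halophenyl like that of compound 1, so much of that large step is expected to reverse, giving a higher number. Compound 4 is therefore estimated at 2000 nM, with a range of 600 nM to 7000 nM. The expected step is an 11-fold higher number from compound 2 to compound 4 (1.04 log units; beyond the scatter).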

Compound 4, half-maximal inhibitory concentration: 1280 nM
Compound 4: middle estimate off by 1.6-fold (0.19 log units), on the high side; the range from low to high includes it.
By their numbers in this assay, from the lowest: compound 2; then compounds 4 and 1 (each within the scatter of the next). At a limit, above all of these: compound 3.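

Replacing 3-fluoro-4-methoxyphenyl with 4-fluorophenyl gives a 7.0-fold higher number from compound 2 to compound 4 (0.84 log units; beyond the scatter), so at this position 3-fluoro-4-methoxyphenyl now stands apart from two halophenyl groups rather than one. Fluoro in place of chloro gives a 1.8-fold lower number from compound 1 to compound 4 (0.26 log units; within the scatter), so the identity of this halogen makes no readable difference in this assay. The data in hand give no cause for either step.

It remains open whether the methoxy or the fluoro of 3-fluoro-4-methoxyphenyl accounts for the difference, as a phenyl carrying only one of them is not among the compounds shown. As far as these compounds go, how an amine or a carboxylic acid on this phenyl ring would read also remains open.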